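Sulfonyl aryl swap and mouse microsomal stability

This account rests on a few compounds, and the source may have more. Where it says the series, first, only, none or still open, it means among the compounds named here.

Within the data shown here, compound 2 `N#C/N=C(\NCc1ccc(S(=O)(=O)c2cccc3cccnc23)cc1)Nc1ccncc1` stands lowest of the two compounds measured so far in an ADME assay on microsomes from liver (Mus musculus) for metabolic stability, with a stated time of 30 min, tested at 1 uM; on this read-out higher numbers stand for a more stable compound and lower numbers for a less stable compound: compound 2 gives 11%, whereas compound 1 `N#C/N=C(\NCc1ccc(S(=O)(=O)c2ccccc2)cc1)Nc1ccncc1` gives 57%. Among the measured compounds shown here, the single measured step in this assay is a number 46 percentage points lower from compound 1 to compound 2 (beyond the scatter), a large drop that followed the arrival of quinolin-8-yl on the sulfonyl sulfur.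

Compound 3 `N#C/N=C(\NCc1ccc(S(=O)(=O)c2cccc(C(F)(F)F)c2)cc1)Nc1ccncc1` differs from compound 2 by the change (3-(trifluoromethyl)phenyl in place of quinolin-8-yl on a sulfonyl sulfur). The step from compound 1 to compound 2 bears directly on this move, since it placed quinolin-8-yl on the same sulfonyl sulfur, and it was large, as shown by a number 46 percentage points lower from compound 1 to compound 2 (beyond the scatter). Taking quinolin-8-yl away again in favour of a carbon-only ring is therefore expected to give a large step upward, a number 39 percentage points higher from compound 2 to compound 3 (beyond the scatter). Compound 3 is estimated at 50%, within 25% to 75%. The trifluoromethyl group has no measured precedent among these compounds, so the range is kept wide.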

Compound 3, percent of the compound remaining in the Mus musculus assay: 74%
Compound 3: middle estimate off by 24 percentage points, on the low side, and the stated range covers the measured number.
By their numbers in the Mus musculus assay, from the lowest: compound 2; then compound 1; then compound 3.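

In the Mus musculus assay the sulfonyl sulfur position tolerates far more range than the first pair showed (a number 63 percentage points higher from compound 2 to compound 3 (beyond the scatter)), and the carbon-only ring does not merely return to the level of the unsubstituted phenyl (a number 17 percentage points higher from compound 1 to compound 3 (beyond the scatter)). In a physicochemical assay for solubility, with a stated time of 24 h (on this read-out higher numbers stand for higher solubility and lower numbers for lower solubility), compound 2 gives 18000 nM and compound 3 gives 28000 nM with no difference beyond the scatter (a 1.6-fold higher number from compound 2 to compound 3 (0.19 log units; within the scatter)), so this change moves stability without a readable shift in solubility. Nothing available explains either step.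

Trifluoromethyl is the only substituent shown on the carbon-only ring, so it stays open whether a methoxy group, an amine or a carboxylic acid in its place would keep the gain over compound 1. Also open, going by these compounds, is whether the low number of compound 2 follows from the ring nitrogen of quinolin-8-yl or from its second ring.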